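This account rests on a few compounds, and the source may have more. Where it says the series, first, only, none or still open, it means among the compounds named here.

In a functional assay on PC-3 cells (Homo sapiens) for antiproliferative activity, read by sulforhodamine B assay, with a stated time of 3 days (a higher number here means that more compound is needed for the effect, a lower number that less compound is needed), compound 1 `CCCC1=C(OCCC(C)C)C(CCC)(CCC)C(=O)/C(=C(O)\C=C\c2ccccc2)C1=O` gives 17 uM. Compound 2 `COC1=C(CC=C(C)C)C(=O)/C(=C(O)/C=C/c2ccccc2)C(=O)C1(CC=C(C)C)CC=C(C)C`, measured the same way, gives 12.2 uM; these two numbers lie within the usual scatter of each other, so no difference between them can be claimed. Compound 3 `CCCC1=C(OCC)C(CCC)(CCC)C(=O)/C(=C(O)\C=C\c2ccccc2)C1=O` has not yet been measured. It differs from compound 1 in one place: hydrogen in place of isopropyl on a saturated chain carbon, two bonds along the chain from an oxygen on an unsaturated carbon. Among the compounds with values here, no pair of measured compounds shows what such a change does, so no shift beyond the scatter is expected in either direction; the estimated step is a 1.2-fold higher number from compound 1 to compound 3 (0.07 log units; within the scatter). For compound 3 the expected value in this assay is 20 uM, within a range from 8 uM to 50 uM.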

Compound 3, concentration for half-maximal effect: 12.5 uM
Estimate against measurement, compound 3: 1.6-fold (0.20 log units) above; the range from low to high includes it.
By their numbers in this assay, from the lowest: compounds 2, 3 and 1 (each within the scatter of the next).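

Within the data shown here, exchanging isopentyloxy for ethoxy gives a 1.4-fold lower number from compound 1 to compound 3 (0.13 log units; within the scatter) in this assay, and this is the first pair of compounds that tests this position. At this saturated chain carbon, the isopropyl can therefore be replaced by hydrogen with no difference that can be told from the scatter. No measurement shown offers an explanation for this result. What the compounds shown leave open is whether a carboxylic acid or an amine at the end of this chain, or a chain longer than isopentyloxy, would take the number beyond the scatter.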